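The source may report more compounds than this note shows. Statements on the series, on what has been measured and on what is new or still open speak of the compounds shown alone.

Measured so far:
Compound 1, `CC(=O)OCCOn1cnc2c(Cl)nc(N)nc21`, in a functional assay on FM3A cells (Homo sapiens) for inhibition, with FM3A (Mus musculus) as the target (a higher number here means a weaker inhibitor, a lower number a stronger inhibitor), gives > 500000 nM, which is a limit of the assay and not a number.
Compound 2, `CC(=O)OCCOn1cnc2c(S)nc(N)nc21`, in this assay gives 2000 nM.

Going by the values given here, compound 2 is thus the only compound with an actual number in this assay; the one other result is a limit. Among the compounds with values here, the single measured step, an at least 250-fold lower number from compound 1 to compound 2 (2.39 log units; beyond the scatter), joins these two compounds, and compound 1 sits at the limit of > 500000 nM in this assay, at which 1 of the 2 values shown sits.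

Compound 3, `CC(=O)OCCOn1cnc2c(S)nc(F)nc21`, is not yet measured. It differs from compound 2 by fluoro in place of amino on an aromatic carbon. Within the data shown here, no measured step bears on this change: the only step known here swaps one group for another elsewhere on the shared core, and nothing measured shows an amino group giving way to a fluoro group. Any expectation for compound 3 therefore rests on no comparable step and must carry a wide range. Compound 3 is expected to give roughly 10000 nM in this assay, with a plausible span from 1000 nM to 150000 nM. That estimate means an expected step of a 5.0-fold higher number from compound 2 to compound 3 (0.70 log units; beyond the scatter), leaning toward a higher number, though with little to anchor it.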

Compound 3, half-maximal inhibitory concentration: 136000 nM
Beside the measured number, compound 3's estimate is 14-fold (1.13 log units) below it; the range from low to high includes it.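

In this assay, the amino group on the aromatic carbon between two ring nitrogen atoms proves to matter a great deal: with the sulfanyl group kept, fluoro in place of amino gives a 68-fold higher number from compound 2 to compound 3 (1.83 log units; beyond the scatter). Going by these compounds alone, the earlier step showed only the exchange of chloro for sulfanyl at another place on the shared core, so this is the first sign that this second place can also move the number a long way, here toward a weaker inhibitor. Nothing measured here explains why the change from amino to fluoro has so large an effect.

The compounds shown leave open whether another group at this place, such as methylamino, hydroxyl or a plain hydrogen, would keep the number nearer that of compound 2, 2000 nM. Also open, from the compounds shown here alone, is whether fluoro in place of amino would have a step of similar size with a group other than sulfanyl on the shared core, such as a methoxy group or an amine.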